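This account rests on a few compounds, and the source may have more. Where it says the series, first, only, none or still open, it means among the compounds named here.

Among the compounds with values here, in a functional assay on blood (Homo sapiens), with a stated time of 60 min, in the presence of a further agent that is not named here (on this read-out higher numbers stand for an effect only at larger amounts of compound and lower numbers for an effect already at smaller amounts), compound 1 `Nc1ccccc1NC(=O)C1(S(=O)(=O)c2ccc(Oc3ccc(OC(F)(F)F)cc3)cc2)CCC2(CCNCC2)C1` gives 900 nM and compound 2 `COc1ccc(N)c(NC(=O)C2(S(=O)(=O)c3ccc(Oc4ccc(OC(F)(F)F)cc4)cc3)CCC3(CCNCC3)C2)c1` gives 3700 nM, the higher of the two numbers so far. Compound 3 `Nc1ccc(-c2cccs2)cc1NC(=O)C1(S(=O)(=O)c2ccc(Oc3ccc(OC(F)(F)F)cc3)cc2)CCC2(CCNCC2)C1` differs from compound 2 by thiophen-2-yl in place of methoxy on an aromatic carbon: thiophen-2-yl in place of methoxy, para to an amino group. Within the data shown here, only one measured step bears on this aromatic carbon, the modest 4.1-fold higher number from compound 1 to compound 2 (0.61 log units; beyond the scatter), with methoxy in place of hydrogen. No measurement covers thiophen-2-yl, so on the evidence of that step for compound 2 only a modest further rise in this assay is expected. The expected size is a 1.4-fold higher number from compound 2 to compound 3 (0.13 log units; within the scatter), which is uncertain. For compound 3 the estimated value is 5000 nM, within an expected range of 1500 nM to 17000 nM.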

Compound 3, half-maximal effective concentration: 900 nM
Estimate against measurement, compound 3: 5.6-fold (0.74 log units) above, outside the stated range (below it).
By their numbers in this assay, from the lowest: compounds 1 and 3 (each within the scatter of the next); then compound 2.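

Position para to an amino group, in this assay: thiophen-2-yl in place of hydrogen leaves the number unchanged (no change at the digits printed from compound 1 to compound 3 (within the scatter)), so a substituent here does not by itself raise it. Methoxy is therefore not representative of this aromatic carbon, and exchanging it for thiophen-2-yl reverses its rise (a 4.1-fold lower number from compound 2 to compound 3 (0.61 log units; beyond the scatter)). Nothing available accounts for the difference between these two groups.

Open, as far as these compounds go, is whether an amine, a carboxylic acid or a longer chain on this carbon would match thiophen-2-yl or methoxy. Also open, from the compounds shown here alone, is whether a phenyl ring would match thiophen-2-yl.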